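Replacing pyridin-4-yl with amino in compound 1

The compounds below may be only part of what the source reports. "The series", "measured", "known", "first", "only" and "open" are said of these compounds alone.

In an ADME assay on BJ cells (Homo sapiens) for cytotoxicity, with a stated time of 72 h (a higher number here means that more compound is needed for the effect, a lower number that less compound is needed), compound 1 `COc1cc2ncnc(-n3nc(-c4ccncc4)nc3N)c2cc1OC` is recorded as "not determined" (no result reported) and so offers no number to start from. For the measured compounds named here, the only other reading comes from compound 2 `CCOC(=O)CNc1nc(-n2nc(-c3ccccn3)nc2N)c2cc(OC)c(OC)cc2n1`, which carries different groups on a related structure. The result for compound 2 is > 27000 nM and that is a limit of the assay, not a number.

The next structure is compound 3 `COc1cc2ncnc(-n3nc(N)nc3N)c2cc1OC`, which keeps the core of compound 1 and alters one group. The change is amino in place of pyridin-4-yl on an aromatic carbon of a five-membered aromatic ring with 3 nitrogen.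

Going by the values given here, no measured pair shows what such a swap does in this assay and compound 1 gives no baseline. The expectation is therefore modest: no step beyond the scatter, with compound 3 expected to show little effect in this assay, much like the reading for compound 2. For compound 3 the estimated value is 22000 nM with an expected range from 7000 nM to 50000 nM as a rough expectation.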

Compound 3, half-maximal effective concentration: > 33000 nM
Compound 3: no number, only a limit (the forecaster's own chance of this, stated with the estimate: 60%); middle value at least 1.5-fold (0.17 log units) from the limit.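

No step can be read from compound 1 to compound 3, as compound 1 is recorded as "not determined" (no result reported). For compound 3, > 33000 nM is a limit of the assay and not a number. The compounds shown leave open what amino in place of pyridin-4-yl does in this assay.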